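Same Change on a Second Core: Expected Solubility of Compound 4

A few compounds are considered here, and "the series" means these few. Any claim that something is new, unique, unknown or untested is made for them only; others in the source may bear on it.

Measured so far:
Compound 1 `FC(F)(F)c1ccc(-c2ccc3c(NCCCNCc4ccco4)ccnc3c2)cc1` gives 32000 nM.
Compound 2 `c1ccc(Cc2ccc3c(NCCCNCc4ccco4)ccnc3c2)cc1` gives 4200 nM.
Compound 3 `COc1cccc(CNCCCNc2ccnc3cc(-c4ccc(C(F)(F)F)cc4)ccc23)c1O` gives 32000 nM.

All three numbers come from a physicochemical assay for solubility, with a stated time of 18 h, at pH 7.4; on this read-out higher numbers stand for higher solubility and lower numbers for lower solubility. Compound 1 and compound 3 differ only in the group carried on the amine side chain: 2-hydroxy-3-methoxyphenyl in place of furan-2-yl on a saturated chain carbon bound to an amine nitrogen. On this read-out that difference made no change at the digits printed from compound 1 to compound 3 (within the scatter), so the two stand level.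

Compound 2 differs from compound 1 on the other end of the molecule: benzyl in place of 4-(trifluoromethyl)phenyl on an aromatic carbon. This change produced a 7.6-fold lower number from compound 1 to compound 2 (0.88 log units; beyond the scatter).

Compound 4 `COc1cccc(CNCCCNc2ccnc3cc(Cc4ccccc4)ccc23)c1O` has not yet been measured in this assay. It differs from compound 3 by exactly the same change: benzyl in place of 4-(trifluoromethyl)phenyl on an aromatic carbon. The place of the change reads the same in both pairs, so the step from compound 3 to compound 4 repeats the step from compound 1 to compound 2 on the core of compound 3.

The expected step for compound 4 is a 7.6-fold lower number from compound 3 to compound 4 (0.88 log units; beyond the scatter), which rests on the step seen once before because the earlier pair gave a 7.6-fold lower number from compound 1 to compound 2 (0.88 log units; beyond the scatter). The estimate for compound 4 in this assay is therefore 4200 nM, expected to fall between 1500 nM and 12000 nM.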

Compound 4, solubility: 4200 nM
Beside the measured number, compound 4's estimate shows no gap at the digits printed; low and high end bracket the measured number.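

Two cores now give the same answer: in this assay, benzyl in place of 4-(trifluoromethyl)phenyl produced a step on the core of compound 3 (a 7.6-fold lower number from compound 3 to compound 4 (0.88 log units; beyond the scatter)) that matches the earlier one (a 7.6-fold lower number from compound 1 to compound 2 (0.88 log units; beyond the scatter)). The swap of furan-2-yl for 2-hydroxy-3-methoxyphenyl also behaves as it did before, now with benzyl on the aromatic carbon (no change at the digits printed from compound 2 to compound 4 (within the scatter)), so in these four compounds each change reads the same whichever form the other end of the molecule takes. This is a single repeat on two closely related cores, so it does not show that the step would hold on other cores, and nothing here explains why the number moves.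

The compounds shown leave open what other groups on that aromatic carbon would do, for example a carboxylic acid or an amine in place of benzyl. They also leave open whether the same step would appear with a longer chain joining the two amine nitrogens.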